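The compounds below may be only part of what the source reports. "The series", "measured", "known", "first", "only" and "open" are said of these compounds alone.

Working notes on the series, measured in a functional assay on MDA-MB-231 cells (Homo sapiens) for inhibition, read by MTT assay, with a stated time of 48 h; a lower number here means a stronger inhibitor of growth, a higher number a weaker inhibitor of growth 

compound 1 `Oc1ccc(Nc2ncnc3ccc(NC(=S)NCc4ccccc4)cc23)cc1` gives 27000 nM
compound 2 `Oc1ccc(NC(=S)Nc2ccc3ncnc(Nc4cccc(Br)c4)c3c2)cc1` gives 17300 nM

On these two numbers compound 2, at 17300 nM, lies within the scatter of compound 1, so neither can be ranked over the other. Among the measured compounds shown here, the two compounds differ in more than one place, and no measured pair isolates a single change. The data therefore give no direct guide to the size of the next step.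

The next compound to be read is compound 3 `S=C(Nc1cc(Cl)cc(Cl)c1)Nc1ccc2ncnc(Nc3cccc(Br)c3)c2c1`, which carries 3,5-dichlorophenyl in place of 4-hydroxyphenyl on an amide-type nitrogen whose other neighbours are: thiocarbonyl carbon. The counted difference is 3,5-dichlorophenyl in place of 4-hydroxyphenyl on an amide-type nitrogen.

A moderate step toward stronger inhibition of growth is expected, a tentative judgement without a measured precedent in this series. The estimated size is a 2.2-fold lower number from compound 2 to compound 3 (0.33 log units; beyond the scatter). For compound 3 the expected value is 8000 nM, with an estimated range from 2500 nM to 25000 nM. The upper end of that range allows for no real change.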

Compound 3, concentration for 50% growth inhibition: 3000 nM
Estimate against measurement, compound 3: 2.7-fold (0.43 log units) above; measured number inside the range.
By their numbers in this assay, from the lowest: compound 3; then compounds 2 and 1 (each within the scatter of the next).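

On the amide-type nitrogen whose other neighbours are the thiocarbonyl carbon, the change to 3,5-dichlorophenyl in place of 4-hydroxyphenyl gives the series its first comparison that differs in one place: in this assay, the result is a 5.8-fold lower number from compound 2 to compound 3 (0.76 log units; beyond the scatter). Compound 1 and compound 2 could not be ranked and differ in more than one place, whereas this pair shows that the group on this nitrogen can alter growth inhibition by more than the scatter, with the rest of the structure held constant. No measurement bears on the reason for this step.

The step swaps the whole aromatic group, so it does not separate loss of the hydroxyl from gain of the two chlorine atoms, and unsubstituted phenyl, 3-chlorophenyl or 4-chlorophenyl would be needed to divide the effect between them. Also open, going by these compounds, is how this nitrogen tolerates other substituents on the ring, such as a methoxy group, a dimethylamino group or a carboxylic acid, and whether 3,5-dichlorophenyl gives a similar step when the core carries the 4-hydroxyphenyl amino group of compound 1.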